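A few compounds are considered here, and "the series" means these few. Any claim that something is new, unique, unknown or untested is made for them only; others in the source may bear on it.

Measured compounds:
- compound 1 `Cc1ccc(/C=N/n2c(S)nnc2-c2cnccn2)cc1`, 156000 nM
- compound 2 `COc1ccc(/C=N/n2c(S)nnc2-c2cnccn2)cc1OC`, 163000 nM

In an ADME assay on NIH3T3 cells (Mus musculus) for cytotoxicity, read by MTT assay, with a stated time of 24 h (a higher number here means a weaker inhibitor, a lower number a stronger inhibitor), compound 1 gives 156000 nM. Compound 2, which carries the two methoxy groups on its phenyl ring, gives 163000 nM in this assay. Among the compounds with values here, the two numbers lie within the scatter of each other, so the series so far shows no difference between these two compounds; both sit at weak inhibition of cell viability.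

The next compound is compound 3 `Oc1ccc(/C=N/n2c(S)nnc2-c2cnccn2)cc1`. Relative to compound 1 the change is hydroxy in place of methyl on an aromatic carbon. Within the data shown here, no measured pair in the set reports a step for this kind of change, so there is nothing to anchor the size of the step. The expectation is that the step from compound 1 to compound 3 stays within the scatter, a 1.1-fold higher number from compound 1 to compound 3 (0.02 log units; within the scatter), with no direction favoured. On that basis compound 3 is estimated at 165000 nM in this assay, expected to fall between 85000 nM and 320000 nM.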

Compound 3, half-maximal inhibitory concentration: 175000 nM
Compound 3: the middle estimate sits 1.1-fold (0.03 log units) below what was measured; the measured number falls inside the stated range.
By their numbers in this assay, from the lowest: compounds 1, 2 and 3 (each within the scatter of the next).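

In this assay, within the data shown here, the change from 4-methylphenyl to 4-hydroxyphenyl gives a 1.1-fold higher number from compound 1 to compound 3 (0.05 log units; within the scatter) and is the first step that can be read at a single place. At this position, para to a large group, hydroxy in place of methyl adds a hydrogen-bond donor and a hydrogen-bond acceptor, yet the step stays within the scatter, so this change leaves no visible mark on the read-out. Nothing available explains the size of this step or bears on it.

On these data alone, whether an amine, a carboxylic acid or a longer chain such as ethoxy at this same position would also stay within the scatter remains open. So does whether any change to the shared core, rather than to this ring, moves the number.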